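This account rests on a few compounds, and the source may have more. Where it says the series, first, only, none or still open, it means among the compounds named here.

Compound 1 `O=C(Nc1ccc(OC(F)(F)F)cc1)NC1CCN(C(=O)C2CCCOC2)CC1` gives 94 ug/mL in a physicochemical assay for solubility, read by mass spectrometry, in phosphate buffer, with a stated time of 24 h, at pH 7.4 (a higher number here means a more soluble compound, a lower number a less soluble compound), the higher of the two numbers available in the series. Compound 2 `CCOC(=O)N1CCC(NC(=O)Nc2ccc(OC(F)(F)F)c(F)c2)CC1` gives 0.35 ug/mL in this assay, a gap that lies well beyond the scatter. Compound 3 `Cc1ccoc1C(=O)N1CCC(NC(=O)Nc2ccc(OC(F)(F)F)cc2)CC1` differs from compound 1 by 3-methylfuran-2-yl in place of oxan-3-yl on a carbonyl carbon. Among the compounds with values here, no measured pair spans this change, so the expected step rests on compound 1 alone. In this assay a moderate downward step, beyond the scatter, is expected: a 6.3-fold lower number from compound 1 to compound 3 (0.80 log units; beyond the scatter). Compound 3 is therefore estimated at 15 ug/mL, with a range from 3 ug/mL to 60 ug/mL.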

Compound 3, solubility: 0.92 ug/mL
For compound 3 the middle estimate is 16-fold (1.21 log units) above the measured one; measured number below the stated range.
By their numbers in this assay, from the lowest: compound 2; then compound 3; then compound 1.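

In this assay, the group on a carbonyl carbon proves a sensitive place: 3-methylfuran-2-yl in place of oxan-3-yl gives a 100-fold lower number from compound 1 to compound 3 (2.01 log units; beyond the scatter). The heavy-atom, donor and acceptor counts stay the same and neither group carries a net charge, so these counts do not track the read-out in this one pair. Nothing available here bears on the cause of the step. Open, as far as these compounds go, is whether the step follows the five-membered aromatic ring or its methyl, which change together here. Also open, from the compounds shown here alone, is how an amine or a carboxylic acid at this place would read.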